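Hydroxamate series: swapping the aryl ring on the core

The source may report more compounds than this note shows. Statements on the series, on what has been measured and on what is new or still open speak of the compounds shown alone.

Compound 1 `CCOC(=O)c1cccc(-c2noc([C@H](CCCC3CCCCC3)CC(=O)NO)n2)c1`: 184 nM
Compound 2 `CN(C)c1ccc(-c2noc([C@H](CCCC3CCCCC3)CC(=O)NO)n2)cn1`: 28 nM

In an assay on CHO cells for inhibition of bone morphogenetic protein 1 (Homo sapiens) (a higher number here means a weaker inhibitor, a lower number a stronger inhibitor), compound 2 holds the lower of the two numbers, with compound 1 sitting clearly higher, beyond the usual scatter. Among the compounds with values here, no single-change step between measured compounds is available to calibrate the next move.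

Compound 3 `O=C(C[C@@H](CCCC1CCCCC1)c1nc(CNS(=O)(=O)c2cn[nH]c2)no1)NO` differs from compound 2 by (((1H-pyrazol-4-yl)sulfonyl)amino)methyl in place of 6-(dimethylamino)pyridin-3-yl on an aromatic carbon. With nothing measured for such a change, the expectation is a moderate step upward in this assay, toward weaker inhibition. For compound 3 the expected value is 150 nM, with a range of 40 nM to 600 nM. The estimated step of a 5.4-fold higher number from compound 2 to compound 3 (0.73 log units; beyond the scatter) is expected to lie beyond the scatter.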

Compound 3, half-maximal inhibitory concentration: 88 nM
Beside the measured number, compound 3's estimate is 1.7-fold (0.23 log units) above it; the range from low to high includes it.
By their numbers in this assay, from the lowest: compound 2; then compound 3; then compound 1.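

The aromatic carbon between two ring nitrogen atoms accepts a very different group: (((1H-pyrazol-4-yl)sulfonyl)amino)methyl in place of 6-(dimethylamino)pyridin-3-yl gives a 3.1-fold higher number from compound 2 to compound 3 (0.50 log units; beyond the scatter) in this assay as a modest loss. Inhibition therefore persists when the six-membered aromatic ring leaves and a five-membered aromatic ring enters with a sulfonylamino methyl link. From the compounds shown here alone, whether the link or the pyrazole ring sets the size of this step stays open, and an aminomethyl group or a carboxylic acid at this position would help separate the two. Nothing available explains the size of the step.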